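A few compounds are considered here, and "the series" means these few. Any claim that something is new, unique, unknown or untested is made for them only; others in the source may bear on it.

Measured so far: compound 1 `O=C(Nc1ccc(Cl)cc1CN1C(=O)c2ccccc2C1=O)C1CCCCC1` with 1500 nM, and compound 2 `O=C(Nc1ccc(F)cc1CN1C(=O)c2ccccc2C1=O)c1ccccn1` with 1500 nM.

Both were tested in an assay on CHO cells for positive allosteric modulation of metabotropic glutamate receptor 5 (Homo sapiens), read by FLIPR; on this read-out lower numbers stand for an effect already at smaller amounts and higher numbers for an effect only at larger amounts of compound. In this assay compound 1 gives 1500 nM, and compound 2 gives 1500 nM, so the two stand level at the digits shown, and no order between them can be read from these numbers. Within the data shown here, compound 2 carries a pyridin-2-yl on its carbonyl carbon where compound 1 carries a cyclohexyl, and its ring bears fluorine where compound 1 bears chlorine; no single step between the two is known.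

Compound 3 `O=C(Nc1ccc(Cl)cc1CN1C(=O)c2ccccc2C1=O)c1ncccc1O` is not yet measured. It differs from compound 1 in one place: 3-hydroxypyridin-2-yl in place of cyclohexyl on a carbonyl carbon. Among the measured compounds shown here, no step of this kind is on record, so the expectation for the step of a 1.5-fold lower number from compound 1 to compound 3 (0.18 log units; within the scatter) rests on the numbers of compound 1 and compound 2 alone, and it is expected to stay within the scatter. Compound 3 is therefore estimated at 1000 nM, with a range from 300 nM to 4000 nM.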

Compound 3, half-maximal effective concentration: 260 nM
Compound 3: middle estimate off by 3.8-fold (0.59 log units), on the high side; the measured number lies below the stated range.
By their numbers in this assay, from the lowest: compound 3; then compounds 1 and 2 (each within the scatter of the next).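

At this position, on a carbonyl carbon whose other neighbour is an amide-type nitrogen, the group clearly matters: in this assay the change from cyclohexyl to 3-hydroxypyridin-2-yl gives a 5.8-fold lower number from compound 1 to compound 3 (0.76 log units; beyond the scatter) and thus lies beyond the usual scatter. Among these compounds, the earlier compounds offered no step in a single place, so this is the first reading of one change on the shared core. That change brings several differences at once, with an aromatic ring holding a hetero atom replacing a carbon-only ring and with a hydrogen-bond donor and acceptors entering, and no supporting data here separate their contributions.

Still open, going by these compounds, is whether the hydroxy group or the ring nitrogen matters more, which phenyl or 3-hydroxyphenyl in the same place could help separate. Also open, on these data alone, is how 3-methoxypyridin-2-yl or 3-aminopyridin-2-yl would compare there.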